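Fluoro added to the benzoyl ring of compound 2

The source may report more compounds than this note shows. Statements on the series, on what has been measured and on what is new or still open speak of the compounds shown alone.

Compound 1 `Cc1cc(C(=O)N2CCc3c(sc(NCc4ccccc4)c3C#N)C2)[nH]n1` gives 1420 nM in a functional assay on Chem-3 cells for antagonist activity at metabotropic glutamate receptor 1 (Homo sapiens), read by fluorescence and calcium flux; on this read-out higher numbers stand for weaker inhibition and lower numbers for stronger inhibition. Compound 2 `N#Cc1c(NCc2ccccc2)sc2c1CCN(C(=O)c1ccccc1)C2` gives 2820 nM, the higher of the two numbers; the step of a 2.0-fold higher number from compound 1 to compound 2 (0.30 log units; within the scatter) is a change on the carbonyl carbon. Compound 3 `N#Cc1c(NCc2ccccc2)sc2c1CCN(C(=O)c1cccc(F)c1)C2` differs from compound 2 by fluoro in place of hydrogen on an aromatic carbon. Going by the values given here, no measured step touches the benzoyl ring itself, and the one step on record was within the scatter, so for compound 3 no step beyond the scatter is expected, a 1.0-fold lower number from compound 2 to compound 3 (0.00 log units; within the scatter). The estimate for compound 3 is 2800 nM, within the range 1000 nM to 8000 nM.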

Compound 3, half-maximal inhibitory concentration: 2900 nM
Beside the measured number, compound 3's estimate is 1.0-fold (0.02 log units) below it, and the stated range covers the measured number.
By their numbers in this assay, from the lowest: compounds 1, 2 and 3 (each within the scatter of the next, the first and the last beyond it).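

Fluoro on the benzoyl ring gives the first reading for a substituent at this ring, and 3-fluorophenyl leaves the number of compound 2 within the scatter (a 1.0-fold higher number from compound 2 to compound 3 (0.01 log units; within the scatter)). Set against the 3-methyl-1H-pyrazol-5-yl amide, the same change makes a modest gap just beyond the scatter (a 2.0-fold higher number from compound 1 to compound 3 (0.31 log units; beyond the scatter)), whereas the unsubstituted phenyl of compound 2 stayed within it. No measured evidence on these compounds bears on the reason for either reading.

Still open, on these data alone, is whether fluoro on other carbons of this ring reads the same. Also open, as far as these compounds go, is whether a methoxy group, an amine or a carboxylic acid on this aromatic carbon would shift the number beyond the scatter.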